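The source may report more compounds than this note shows. Statements on the series, on what has been measured and on what is new or still open speak of the compounds shown alone.

Compound 3 `CC/C=C/C(=O)Nc1cccc(Oc2nc(Nc3cccc(C#N)c3)nc3ccsc23)c1` carries a but-1-en-1-yl group on the carbonyl carbon of the shared core. In an ADME assay on L02 cells (Homo sapiens) for inhibition, read by MTT assay, with a stated time of 72 h (on this read-out higher numbers stand for weaker inhibition and lower numbers for stronger inhibition), compound 3 gives > 50000 nM, which is a limit of the assay rather than a number. Compound 1 `C=CC(=O)Nc1cccc(Oc2nc(Nc3cccc(C#N)c3)nc3ccsc23)c1` and compound 2 `CC(C)=CC(=O)Nc1cccc(Oc2nc(Nc3cccc(C#N)c3)nc3ccsc23)c1` have the same core with different groups on that carbonyl carbon. In this assay compound 1 gives > 50000 nM, again a limit. In this assay compound 2 gives > 50000 nM, also a limit. Because the limit of > 50000 nM in this assay, at which 3 of the 3 values shown sit, holds for every value shown, the steps between these compounds cannot be sized: a step that the two limits leave unreadable from compound 1 to compound 2, a step that the two limits leave unreadable from compound 1 to compound 3 and a step that the two limits leave unreadable from compound 2 to compound 3. Compound 4 `CC(C)/C=C/C(=O)Nc1cccc(Oc2nc(Nc3cccc(C#N)c3)nc3ccsc23)c1` differs from compound 3 by methyl in place of hydrogen on a saturated chain carbon bound to a double-bonded chain carbon and a saturated chain carbon. The measured steps bear on this change only in that three neighbouring acylamides all sit at the limit, so no readable step is expected in this assay for compound 4, and a step that the limit leaves unreadable from compound 3 to compound 4 is expected to remain unreadable. Compound 4 is therefore estimated at 100000 nM, within 30000 nM to 500000 nM.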

Compound 4, half-maximal inhibitory concentration: > 50000 nM
Compound 4 was reported as a limit; the forecaster's own chance of this, stated with the estimate: 85%; the middle value does not contradict the limit.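

Compound 4, like compound 1, compound 2 and compound 3, stands only as a limit in this assay, so no new step among these compounds can be read: the limit of > 50000 nM in this assay, at which 4 of the 4 values shown sit.

The compounds shown leave open whether any group on that carbonyl carbon changes the read-out in this assay at all, and by how much.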